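Trifluoromethyl in Place of Phenyl on the Aryl Ketone

A few compounds are considered here, and "the series" means these few. Any claim that something is new, unique, unknown or untested is made for them only; others in the source may bear on it.

Measured compounds:
compound 1 `CC(=O)c1cccc(Nc2ccnc(SCC(=O)c3ccc(-c4ccccc4)cc3)n2)c1`: 22%
compound 2 `CC(=O)c1ccc(Nc2ccnc(SCC(=O)c3ccc(-c4ccccc4)cc3)n2)cc1`: 11%

Within the data shown here, in a functional assay on SK-OV-3 cells (Homo sapiens) for inhibition, read by sulforhodamine B assay, with a stated time of 48 h, tested at 10 uM (on this read-out higher numbers stand for more inhibition of growth at the one concentration tested and lower numbers for less inhibition of growth), compound 1 gives 22%, the higher of the two numbers; the only measured step, a number 11 percentage points lower from compound 1 to compound 2 (beyond the scatter), concerns the acetyl-bearing ring, not the ketone side. Compound 3 `CC(=O)c1cccc(Nc2ccnc(SCC(=O)c3ccc(C(F)(F)F)cc3)n2)c1` differs from compound 1 by trifluoromethyl in place of phenyl on an aromatic carbon. Among the measured compounds shown here, no measured step bears on this change, so nothing known here gives a direction. Compound 3 is therefore expected to stay near compound 1, a step of a number 4 percentage points lower from compound 1 to compound 3 (within the scatter) that lies within the scatter. For compound 3 the estimate is 18%, with a range from 0% to 40%.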

Compound 3, percent growth inhibition at one concentration: 21%
Compound 3: middle estimate off by 3 percentage points, on the low side; the measured number falls inside the stated range.
By their numbers in this assay, from the lowest: compounds 2, 3 and 1 (each within the scatter of the next, the first and the last beyond it).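

In this assay the ketone side gives its first reading, a number 1 percentage points lower from compound 1 to compound 3 (within the scatter), so this position accepts trifluoromethyl in place of phenyl, losing the six-membered aromatic ring without a step beyond the scatter. Nothing available explains why this exchange leaves the number within the scatter.

From the compounds shown here alone, what an amine, a carboxylic acid or a longer chain would give at this same place remains open. So does whether 4-acetylphenyl in place of 3-acetylphenyl would give the same step when trifluoromethyl is present.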